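Dichlorophenyl to 4-chlorophenyl with the bromo retained

The source may hold more compounds than are shown below. What is called first, only, known or untested is meant among the compounds shown, and "the series" means these compounds.

Measured so far in a functional assay on OVCAR-8 cells (Homo sapiens); a lower number here means a stronger inhibitor of growth, a higher number a weaker inhibitor of growth:
compound 1 `O=S(=O)(/C=C/c1ccc(Cl)c(Cl)c1)Cc1ccc(Nc2ncnc3ccccc23)cc1` gives 14000 nM
compound 2 `O=S(=O)(/C=C/c1ccc(O)cc1)Cc1ccc(Nc2ncnc3ccccc23)cc1` gives 1000 nM
compound 3 `O=S(=O)(/C=C/c1ccc(Cl)c(Cl)c1)Cc1ccc(Nc2ncnc3ccc(Br)cc23)cc1` gives 100 nM

Compound 3 holds the lowest number of the three, and its gaps to compound 1 and compound 2 both lie beyond the scatter. The next structure is compound 4 `O=S(=O)(/C=C/c1ccc(Cl)cc1)Cc1ccc(Nc2ncnc3ccc(Br)cc23)cc1`, still unmeasured. The change is hydrogen in place of chloro on an aromatic carbon, with hydrogen in place of chloro on an aromatic carbon, ortho to a chloro group and meta to a large group.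

Among the compounds with values here, two measured steps bear on it, both large. The 3,4-dichlorophenyl group was altered in a 14-fold lower number from compound 1 to compound 2 (1.15 log units; beyond the scatter), but that step put 4-hydroxyphenyl in its place and was measured without the bromo. The bromo itself accounts for a 140-fold lower number from compound 1 to compound 3 (2.15 log units; beyond the scatter), and compound 4 keeps it, so most of that gain is expected to remain. Within the data shown here, no measured pair isolates the loss of this chloro alone, which leaves the direction poorly fixed.

A small step is expected, near the scatter, with a slight lean towards a higher number in this assay. The expected step is a 1.5-fold higher number from compound 3 to compound 4 (0.18 log units; within the scatter) in this assay with a wide margin. For compound 4 the estimated value is 150 nM, with an expected range from 40 nM to 800 nM in this assay.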

Compound 4, concentration for 50% growth inhibition: 3000 nM
Estimate against measurement, compound 4: 20-fold (1.30 log units) below; the measured number lies above the stated range.
By their numbers in this assay, from the lowest: compound 3; then compound 2; then compound 4; then compound 1.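

In this assay, going from 3,4-dichlorophenyl to 4-chlorophenyl with the bromo retained gives a 30-fold higher number from compound 3 to compound 4 (1.48 log units; beyond the scatter), so the chloro ortho to a chloro group and meta to a large group is far from a silent substituent in this bromo-bearing pair. Like a 140-fold lower number from compound 1 to compound 3 (2.15 log units; beyond the scatter), this step is large, which shows that a single-atom change on the aryl group can also shift growth inhibition well beyond the scatter, and that the bromo alone does not secure a low number. Nothing available here explains the size of this step.

Within the data shown here, whether the chloro matters as much without the bromo remains open, since the only comparison for this change comes from the pair compound 3 and compound 4. Also open, from the compounds shown here alone, is whether fluoro, methyl, methoxy or trifluoromethyl in place of the lost chloro would keep the number near that of compound 3 at 100 nM, or whether only chloro serves on this aromatic carbon.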